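A few compounds are considered here, and "the series" means these few. Any claim that something is new, unique, unknown or untested is made for them only; others in the source may bear on it.

Measured compounds:
compound 1 `Cc1nc(O)c2cc(CN(C)c3ccc(C(=O)N[C@@H](CCC(=O)O)C(=O)N(C)[C@@H](CCC(=O)O)C(=O)O)c(F)c3)ccc2n1` — in an assay on L1210 cells for inhibition of Thymidylate synthase (Mus musculus) (a lower number here means a stronger inhibitor, a higher number a weaker inhibitor), compound 1 gives 23 nM
compound 2 `Cc1nc(O)c2cc(CN(C)c3ccc(C(=O)N[C@@H](CCC(=O)O)C(=O)N(C)[C@@H](CCC(=O)O)C(=O)O)c(F)c3)c(C)cc2n1` — in this assay compound 2 gives 3 nM

For the measured compounds named here, compound 2 holds the lowest of the two numbers; the only measured step, a 7.7-fold lower number from compound 1 to compound 2 (0.88 log units; beyond the scatter), concerns a methyl in place of hydrogen on the shared core. Compound 3 `Cc1nc(O)c2cc(CN(C)c3ccc(C(=O)N[C@@H](CCC(=O)O)C(=O)N(C)[C@@H](CCC(=O)O)C(=O)O)cc3)c(C)cc2n1` differs from compound 2 by hydrogen in place of fluoro on an aromatic carbon. Going by the values given here, no measured step touches this position, so the series gives no direct guide to the size of the change; a step within the scatter or a small rise in number is expected. Compound 3 is expected at 6 nM, with a range of 2 nM to 18 nM, meaning a 2.0-fold higher number from compound 2 to compound 3 (0.30 log units; within the scatter).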

Compound 3, inhibition constant: 8.2 nM
Beside the measured number, compound 3's estimate is 1.4-fold (0.14 log units) below it, and the stated range covers the measured number.
By their numbers in this assay, from the lowest: compound 2; then compound 3; then compound 1.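

Hydrogen in place of fluoro on this aromatic carbon gives a 2.7-fold higher number from compound 2 to compound 3 (0.44 log units; beyond the scatter) in this assay, so this position, untouched by the earlier step, does respond to the change, and fluoro carries the lower number of the two groups here. This reading rests on a single pair, with the methyl present on the shared core. Nothing available accounts for the size of the step. As far as these compounds go, whether the same step holds without that methyl stays open. Also open, from the compounds shown here alone, is how chloro, a methoxy group or an amine would compare on this aromatic carbon.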